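The source may report more compounds than this note shows. Statements on the series, on what has been measured and on what is new or still open speak of the compounds shown alone.

The study measures inhibition in an assay on HeLa cells for inhibition of Indoleamine 2,3-dioxygenase 1 (Homo sapiens), with a stated time of 20 h; on this read-out lower numbers stand for stronger inhibition and higher numbers for weaker inhibition. Of the compounds shown here, two have been tested. Compound 1, with the structure `CC(C)(C)c1ccccc1Oc1ccc(-c2cccc(C(=O)O)c2)cc1NC(=O)Nc1ccc(OC(F)F)cc1`, gives 2600 nM in this assay. Compound 2, with the structure `COc1ccc(-c2ccc(Oc3ccccc3C)c(NC(=O)Nc3ccc(C)cc3)c2)cc1C(=O)O`, gives 840 nM in this assay. Compound 2 therefore holds the lower of the two numbers, and the gap to compound 1 is wider than the usual scatter, so compound 2 is the more potent of the pair on these readings.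

Compound 3, with the structure `COc1ccc(-c2ccc(Oc3ccccc3C(C)(C)CO)c(NC(=O)Nc3ccc(C)cc3)c2)cc1C(=O)O`, has not yet been measured. It differs from compound 2 in one place: 1-(hydroxymethyl)-1-methylethyl in place of methyl on an aromatic carbon. Within the data shown here, no step between measured compounds matches this change, so nothing in the data fixes its size or direction. The step from compound 2 to compound 3 in this assay, a 1.1-fold higher number from compound 2 to compound 3 (0.03 log units; within the scatter), is expected to stay close to the scatter, with no clear direction favored. Compound 3 is therefore estimated to give about 900 nM in this assay, within a range from 300 nM to 2700 nM.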

Compound 3, half-maximal inhibitory concentration: 2400 nM
Beside the measured number, compound 3's estimate is 2.7-fold (0.43 log units) below it; the range from low to high includes it.
By their numbers in this assay, from the lowest: compound 2; then compounds 3 and 1 (each within the scatter of the next).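

In this assay, among these compounds, the aromatic carbon ortho to a large group proves sensitive to what it carries, which the earlier compounds could not show, as compounds 1 and 2 differ in more than one place. Replacing methyl with 1-(hydroxymethyl)-1-methylethyl gives a 2.9-fold higher number from compound 2 to compound 3 (0.46 log units; beyond the scatter) and so weakens inhibition by a modest margin, beyond the usual scatter, in a change that adds carbons along with one hydrogen-bond donor and one acceptor. Nothing shown here gives a measured reason for this step. Among the compounds shown here, the single step cannot say whether the added carbons, the branching or the hydroxyl oxygen accounts for the loss, because all three enter together in compound 3. The compounds shown also leave open how an ethyl, a hydroxymethyl or a methoxy group would behave on this same carbon, and whether such a group would leave the number closer to that of compound 2.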